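The compounds below may be only part of what the source reports. "The series", "measured", "known", "first", "only" and "open" are said of these compounds alone.

In an ADME assay on HEK293 cells (Homo sapiens) for antiproliferative activity, read by MTT assay, with a stated time of 24 h (on this read-out higher numbers stand for weaker inhibition and lower numbers for stronger inhibition), compound 1 `COc1ccc(-c2cc(C(=O)/C=C/c3ccccc3)nc3cc(-c4ccccc4)nn23)cc1OC` gives 64100 nM. Compound 2 `COc1ccc(-c2cc(C(=O)/C=C/c3ccc(C)cc3)nc3cc(-c4ccccc4)nn23)cc1OC` gives 57400 nM in this assay, and compound 3 `COc1ccc(-c2cc(/C=C/C(=O)c3ccc(C)cc3)nc3cc(-c4ccccc4)nn23)cc1OC` gives 62600 nM. The three numbers sit close together: the step of a 1.1-fold lower number from compound 1 to compound 2 (0.05 log units; within the scatter) and the step of a 1.1-fold higher number from compound 2 to compound 3 (0.04 log units; within the scatter) are both within the scatter, as is the step of a 1.0-fold lower number from compound 1 to compound 3 (0.01 log units; within the scatter). Among the compounds with values here, compound 3 therefore stands in the middle of a flat group, with no compound set apart from it.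

Compound 4 `COc1ccc(C(=O)/C=C/c2cc(-c3ccc(OC)c(OC)c3)n3nc(-c4ccccc4)cc3n2)cc1OC` is reached from compound 3 by the change (3,4-dimethoxyphenyl in place of 4-methylphenyl on a carbonyl carbon). Within the data shown here, no measured step touches the ring on the carbonyl side in this way; the closest comparison is the step from compound 1 to compound 2, where a methyl was added to the ring on the ethenyl side and the number moved only within the scatter. The rearrangement of the carbonyl and ethenyl groups between compound 2 and compound 3 also left the number where it was. Nothing in these three compounds points to a shift in this assay, so compound 4 is expected to stay in the same flat band, and the step of a 1.0-fold lower number from compound 3 to compound 4 (0.02 log units; within the scatter) is estimated to lie within the scatter. Compound 4 is accordingly estimated at 60000 nM, with a range from 30000 nM to 120000 nM.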

Compound 4, half-maximal inhibitory concentration: 32500 nM
Estimate against measurement, compound 4: 1.8-fold (0.27 log units) above; measured number inside the range.
By their numbers in this assay, from the lowest: compounds 4, 2, 3 and 1 (each within the scatter of the next).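

In this assay, putting 3,4-dimethoxyphenyl in place of 4-methylphenyl on a carbonyl carbon whose other neighbour is a double-bonded chain carbon gives a 1.9-fold lower number from compound 3 to compound 4 (0.28 log units; within the scatter). This is the only step among these compounds that alters the group on this carbonyl carbon alone, and although it is larger in size than a 1.1-fold lower number from compound 1 to compound 2 (0.05 log units; within the scatter), it still lies within the scatter, so this position takes two methoxy groups in exchange for a methyl without a change that can be read from this one pair. Nothing measured on either group bears on this result, so no reason for it can be offered.

The compounds shown leave open whether the position responds at all to groups of a different kind, such as an amine, a carboxylic acid or a longer chain on this ring. They also leave open whether 3,4-dimethoxyphenyl would give a similar step on the ethenyl side of the chain, or whether a single methoxy group would do the same as the two in compound 4.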